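Methyl to methoxy on compound 2: clearance expectation

A few compounds are considered here, and "the series" means these few. Any claim that something is new, unique, unknown or untested is made for them only; others in the source may bear on it.

compound 1 `Cc1cc(C)c(CN2CCc3c(Cl)cc([C@@H](CO)[C@@H]4CCOC4)c(Cl)c3C2=O)c(=O)[nH]1`: 25.3 uL/min
compound 2 `Cc1cc(C)c(CN2CCc3c(Cl)cc(-c4c(C)noc4C)c(Cl)c3C2=O)c(=O)[nH]1`: 107 uL/min
compound 3 `Cc1cc(C)c(CN2CCc3c(Cl)cc([C@H](C)CO)c(Cl)c3C2=O)c(=O)[nH]1`: 15.8 uL/min

In an ADME assay on microsomes from liver (Homo sapiens) for metabolic stability, read by LC-MS, using NADPH, with stated times of 10 min and 45 min, tested at 1 uM (a higher number here means faster removal of the compound, a lower number slower removal), compound 2 gives 107 uL/min, the highest of the three numbers. The step of a 4.2-fold higher number from compound 1 to compound 2 (0.63 log units; beyond the scatter) and the step of a 6.8-fold lower number from compound 2 to compound 3 (0.83 log units; beyond the scatter) set compound 2 apart from the other two, both beyond the scatter, while a 1.6-fold lower number from compound 1 to compound 3 (0.20 log units; within the scatter) lies within it. Compound 4 `COc1cc(C)[nH]c(=O)c1CN1CCc2c(Cl)cc(-c3c(C)noc3C)c(Cl)c2C1=O` differs from compound 2 by methoxy in place of methyl on an aromatic carbon. Going by the values given here, none of the measured steps alters the ring where this change sits: each of them alters the group on an aromatic carbon of the shared core, and the six-membered aromatic ring with 1 nitrogen is unchanged across compounds 1, 2 and 3. Among the compounds with values here, no measured step bears on the change from compound 2 to compound 4, so no step beyond the scatter is expected in this assay, in either direction. The estimated value for compound 4 is 100 uL/min, with a range from 50 uL/min to 200 uL/min. The expected step is a 1.1-fold lower number from compound 2 to compound 4 (0.03 log units; within the scatter).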

Compound 4, intrinsic clearance in a liver preparation (reported as CLH), per the amount of preparation that the assay uses: 70 uL/min
Compound 4: the middle estimate sits 1.4-fold (0.15 log units) above what was measured; the measured number falls inside the stated range.
By their numbers in this assay, from the lowest: compounds 3 and 1 (each within the scatter of the next); then compounds 4 and 2 (each within the scatter of the next).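

The swap of methyl for methoxy on the aromatic carbon opposite the ring nitrogen, the only change in this ring among these compounds, gives in this assay a 1.5-fold lower number from compound 2 to compound 4 (0.18 log units; within the scatter) and so stays within the scatter. Going by these compounds alone, at this position, on the background of compound 2, the added oxygen therefore brings no step of the size seen on changing the group on the shared core, such as a 6.8-fold lower number from compound 2 to compound 3 (0.83 log units; beyond the scatter) and no such step is seen at this ring. Nothing on hand offers a reason for the size of the step from methyl to methoxy.

As far as these compounds go, whether methoxy at this position reads the same with the 1-(hydroxymethyl)ethyl group of compound 3 in place of 3,5-dimethyl-1,2-oxazol-4-yl stays open. Also open, from the compounds shown here alone, is how a longer ether such as ethoxy, an amine or a nitrile on this carbon would read in this assay on the same core.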